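From Bromophenyl to Dichlorophenyl on a Shared Core

The source may hold more compounds than are shown below. What is called first, only, known or untested is meant among the compounds shown, and "the series" means these compounds.

Compound 1 `CO[C@@]12CCN(C)C[C@H]1[C@H](c1ccc(Br)cc1)C(C#N)=C(N)O2` was tested in a functional assay on trachea (Cavia porcellus) (on this read-out higher numbers stand for weaker inhibition and lower numbers for stronger inhibition), where compound 1 gives 7900 nM. Compound 2 `CCN1CC[C@@]2(OC)OC(N)=C(C#N)[C@@H](c3ccc(Br)cc3)[C@@H]2C1` gives 13200 nM and compound 3 `CCCN1CC[C@@]2(OC)OC(N)=C(C#N)[C@@H](c3ccc(Br)cc3)[C@@H]2C1` gives 19400 nM, so compound 1 has the lowest number of the three, though the step of a 1.7-fold higher number from compound 1 to compound 2 (0.22 log units; within the scatter) stays within the scatter and only a 2.5-fold higher number from compound 1 to compound 3 (0.39 log units; beyond the scatter) reaches beyond it. Compound 4 `CO[C@@]12CCN(C)C[C@H]1[C@H](c1ccc(Cl)cc1Cl)C(C#N)=C(N)O2` differs from compound 1 in one place: 2,4-dichlorophenyl in place of 4-bromophenyl on a saturated ring carbon. Within the data shown here, all the measured steps, including a 1.5-fold higher number from compound 2 to compound 3 (0.17 log units; within the scatter), change the group on the ring nitrogen, not the group on the saturated ring carbon, so none of them bears on this change. With nothing to lean on, the expected step for compound 4 is a 1.1-fold lower number from compound 1 to compound 4 (0.05 log units; within the scatter), none beyond the scatter. Compound 4 is therefore estimated at 7000 nM, with a range from 2000 nM to 25000 nM.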

Compound 4, half-maximal inhibitory concentration: 14900 nM
The estimate for compound 4 lay 2.1-fold (0.33 log units) below the measured number; the range from low to high includes it.
By their numbers in this assay, from the lowest: compounds 1, 2, 4 and 3 (each within the scatter of the next, the first and the last beyond it).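

In this assay, putting 2,4-dichlorophenyl in place of 4-bromophenyl on the saturated ring carbon gives a 1.9-fold higher number from compound 1 to compound 4 (0.28 log units; within the scatter). This is the only step shown at this position, and it means that these two halogen-bearing phenyl groups cannot be told apart on this read-out. Nothing measured here offers a reason for this result.

Still open, as far as these compounds go, is whether a phenyl ring carrying an amine or a carboxylic acid would shift the number beyond the scatter. From the compounds shown here alone, it is also open whether 2,4-dichlorophenyl would behave the same way alongside the longer chains on the ring nitrogen.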